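Allyl in Place of Propargyl on an Amide Nitrogen

The compounds below may be only part of what the source reports. "The series", "measured", "known", "first", "only" and "open" are said of these compounds alone.

Compound 1 `C#CCNC(=O)/C(C)=C(\C)c1ccccc1` and compound 2 `C#CCNC(=O)/C(C)=C(\C)c1ccc(F)cc1` share one core and differ only by a fluoro in place of hydrogen on an aromatic carbon. In a toxicity assay on the whole organism (strain Icem-CET (SPF Caw)) for cytotoxicity, with Mus musculus as the target (a lower number here means that less compound is needed, a higher number that more compound is needed for the effect), compound 1 gives 150 mg/kg, and compound 2 gives 100 mg/kg. For the measured compounds named here, the step of a 1.5-fold lower number from compound 1 to compound 2 (0.18 log units; within the scatter) cannot be separated from repeat scatter, so compound 1 stands beside its only neighbour, compound 2, with no real gap between them.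

Compound 3 `C=CCNC(=O)/C(C)=C(\C)c1ccccc1` differs from compound 1 by vinyl in place of ethynyl on a saturated chain carbon bound to an amide-type nitrogen. Going by the values given here, no measured step touches this part of the molecule; the one step known, a 1.5-fold lower number from compound 1 to compound 2 (0.18 log units; within the scatter), concerns the aromatic ring and stays within the scatter. Nothing measured therefore points in either direction, and compound 3 is expected to sit near compound 1, with the step of no change at the digits printed from compound 1 to compound 3 (within the scatter) expected to remain within the scatter. Compound 3 is estimated at 150 mg/kg, with a range from 75 mg/kg to 300 mg/kg.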

Compound 3, dose for half-maximal effect: 250 mg/kg
Estimate against measurement, compound 3: 1.7-fold (0.22 log units) below, within the range that was stated.
By their numbers in this assay, from the lowest: compounds 2, 1 and 3 (each within the scatter of the next, the first and the last beyond it).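

Replacing propargyl with allyl on the amide nitrogen gives a 1.7-fold higher number from compound 1 to compound 3 (0.22 log units; within the scatter) in this assay. For the compounds shown here, this is the first measured change away from the aromatic ring, and it shows that vinyl can stand in place of ethynyl on this saturated chain carbon without a step that can be told apart from repeat scatter. No measurement is available that could explain this result or link it to either group.

The compounds shown leave open what happens at this position with a fully saturated propyl chain, a longer butyl chain, or a benzyl group, any of which might move the number beyond the scatter. They also leave open whether allyl in place of propargyl reads the same on the core of compound 2, which carries the fluoro.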